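Chloro to cyano on the five-membered ring: lipophilicity notes

A few compounds are considered here, and "the series" means these few. Any claim that something is new, unique, unknown or untested is made for them only; others in the source may bear on it.

Measured so far:
compound 1 `CCCC(Oc1ccc(-n2cc(Cl)cn2)cc1)c1ccc(C(=O)NCCC(=O)O)cc1` — 2.6
compound 2 `CCC(Oc1ccc(-n2cc(C(F)(F)F)cn2)cc1)c1ccc(C(=O)NCCC(=O)O)cc1` — 1.9
compound 3 `CCCC(Nc1cc(C)c(-n2cc(C(F)(F)F)cn2)c(C)c1)c1ccc(C(=O)NCCC(=O)O)cc1` — 2.2

In a physicochemical assay for lipophilicity, using the shake flask method, at pH 7.4 (on this read-out lower numbers stand for lower lipophilicity and higher numbers for higher lipophilicity), compound 1 gives 2.6, the highest of the three numbers. Compound 3 sits nearest, with 2.2, a gap beyond the scatter. Compound 2 sits furthest, with 1.9, also beyond the scatter. Among the measured compounds shown here, neither of these two compounds differs from compound 1 in a single place, so no step between measured compounds is available, and the gaps say only what the two values show.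

Compound 4 `CCCC(Oc1ccc(-n2cc(C#N)cn2)cc1)c1ccc(C(=O)NCCC(=O)O)cc1` differs from compound 1 by cyano in place of chloro on an aromatic carbon. For the measured compounds named here, no measured pair shows this change, so its size cannot be read from the set; the three compounds measured all carry either chloro or trifluoromethyl at that place, none cyano.

In this assay a step downward from compound 1 is expected, of a size beyond the scatter. Compound 4 is estimated at 1.8, with a range from 1.3 to 2.3. The expected step is a number 0.80 log units lower from compound 1 to compound 4 (beyond the scatter). A measured value for compound 4 will show whether this expectation holds.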

Compound 4, distribution coefficient: 1.2
Compound 4: the middle estimate sits 0.60 log units above what was measured; measured number below the stated range.
By their numbers in this assay, from the lowest: compound 4; then compounds 2 and 3 (each within the scatter of the next); then compound 1.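

In this assay, among the compounds shown here, this is the first reading of a single change: a number 1.40 log units lower from compound 1 to compound 4 (beyond the scatter), a large step with cyano in place of chloro and the core of compound 1 otherwise unchanged. The earlier compounds shown here differ from one another in more than one place, so they could not isolate this position; the pair now shows that the read-out is highly sensitive to the group on this aromatic carbon of the five-membered aromatic ring, even though the exchange is small on paper, with 1 heavy atom leaving, 2 heavy atoms entering, and no ring or net charge in either group. Nothing measured here accounts for the size of the step.

Still open, as far as these compounds go, is how other groups at this place would read, such as bromo, methoxy or an amine, and so whether chloro and cyano mark the ends of a wider range or only two points within it. Also open, from the compounds shown here alone, is whether the same exchange gives a step of similar size on the cores of compound 2 and compound 3.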